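From Compound 3 to Compound 4: a Pyridin-4-yl Replacement

The source may report more compounds than this note shows. Statements on the series, on what has been measured and on what is new or still open speak of the compounds shown alone.

Of the compounds shown here, three have so far been tested in a functional assay on KYSE-410 cells (Homo sapiens) for antiproliferative activity, read by MTT assay, with a stated time of 72 h; on this read-out higher numbers stand for weaker inhibition and lower numbers for stronger inhibition: compound 1 `O=C(c1cc(=O)[nH]c2cc(Br)ccc12)N1CCCCC1`, compound 2 `COc1ccc(NC(=O)c2cc(=O)[nH]c3cc(Br)ccc23)cc1` and compound 3 `CC(C)(C)c1ccc(-c2ccc3c(C(=O)Nc4cccc(F)c4)cc(=O)[nH]c3c2)cc1`. In this assay compound 1 gives > 20000 nM, which is a limit of the assay and not a number. Compound 2 likewise gives > 20000 nM in this assay, again a limit. For compound 3 this assay records > 20000 nM, also a limit. Compound 3 therefore stands where every other compound stands: at the limit of > 20000 nM in this assay, at which 3 of the 3 values shown sit. For the measured compounds named here, since no compound has a numerical value, no step between measured compounds can be sized, and no direction of change has been seen.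

Compound 4 `O=C(Nc1cccc(F)c1)c1cc(=O)[nH]c2cc(-c3ccncc3)ccc12` is the next compound for this assay. It differs from compound 3 in one place: pyridin-4-yl in place of 4-(tert-butyl)phenyl on an aromatic carbon. With nothing measured beyond the limit, there is no basis for expecting compound 4 to behave differently from compound 3, so the step from compound 3 to compound 4 is estimated as a number no higher from compound 3 to compound 4 (the limit leaves the size open), that is none beyond the scatter. Compound 4 is accordingly expected to give about 20000 nM in this assay, with a range from 5000 nM to 40000 nM, most probably reported again only as a limit.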

Compound 4, half-maximal inhibitory concentration: > 20000 nM
Compound 4: no number, only a limit (the forecaster's own chance of this, stated with the estimate: 70%); the middle value lies on the limit itself.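

In this assay, compound 3 and compound 4 both sit at a limit and not at a number, so no step between them can be read: the limit of > 20000 nM in this assay, at which 4 of the 4 values shown sit.

The compounds shown leave open whether pyridin-4-yl in place of 4-(tert-butyl)phenyl, or any other change to the shared core, has an effect that can be read as a number in this assay.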